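Swapping methyl for chloro on compound 1's aromatic ring

A few compounds are considered here, and "the series" means these few. Any claim that something is new, unique, unknown or untested is made for them only; others in the source may bear on it.

Going by the values given here, compound 1 `Cc1ccc(S(=O)(=O)N2C(=O)CCC2C(=O)NN)cc1` gives 50.1% in a functional assay on the whole organism (Ehrlich cells) with Mus musculus as the target, at a dose of 50 mg/kg by the intraperitoneal route (on this read-out lower numbers stand for less inhibition and higher numbers for more inhibition at the one dose given (going by the name of the read-out)), the lower of the two numbers measured so far. Compound 2 `Cc1ccc(S(=O)(=O)N2C(=O)CCC2C(=O)NNc2ccccc2)cc1` gives 77.6%, and the step of a number 27.5 percentage points higher from compound 1 to compound 2 (beyond the scatter) came with phenyl in place of hydrogen on an amine nitrogen. Compound 3 `NNC(=O)C1CCC(=O)N1S(=O)(=O)c1ccc(Cl)cc1` differs from compound 1 only by chloro in place of methyl on an aromatic carbon. Among the compounds with values here, the one step measured concerns the amine nitrogen, not the aromatic ring, so it does not bear on this change, and no move beyond the scatter is expected. Compound 3 is therefore estimated at 50% (range 35% to 65%), which means an expected step of a number 0.1 percentage points lower from compound 1 to compound 3 (within the scatter).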

Compound 3, a percentage reported as inhibition, in the whole organism at one dose (the size of the read-out at that dose, not a potency): 64.9%
Compound 3: the middle estimate sits 14.9 percentage points below what was measured, and the stated range covers the measured number.
By their numbers in this assay, from the lowest: compound 1; then compound 3; then compound 2.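

In this assay, the aromatic carbon para to a large group proves responsive, since chloro in place of methyl there gives a number 14.8 percentage points higher from compound 1 to compound 3 (beyond the scatter). The earlier compounds had shown a change only on the amine nitrogen, so this is the first sign that the aromatic ring also matters to this read-out. Nothing at hand explains the move. The compounds shown leave open how a methoxy group or an amine at the same carbon would read. They also leave open whether chloro on the ring and phenyl on the amine nitrogen would add together.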